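Swapping the aryl group on a shared core

The source may hold more compounds than are shown below. What is called first, only, known or untested is meant among the compounds shown, and "the series" means these compounds.

Measured compounds:
Compound 1, `CCC1=C(O)c2c(oc(-c3ccc(Br)cc3)cc2=O)C(CC)(CC)C1=O`: 15.7 uM
Compound 2, `CCC1=C(O)c2c(oc(-c3ccc(C)cc3C)cc2=O)C(CC)(CC)C1=O`: 8.52 uM

Both compounds were tested in a functional assay on KBVIN cells (Homo sapiens) for antiproliferative activity, read by sulforhodamine B assay, with a stated time of 3 days; a higher number here means that more compound is needed for the effect, a lower number that less compound is needed. Among the compounds with values here, compound 2 sits at one end of the two numbers, and its only neighbour is compound 1; the step of a 1.8-fold lower number from compound 1 to compound 2 (0.27 log units; within the scatter) lies within the scatter, so the two compounds cannot be told apart on this evidence. Compound 3, `CCC1=C(O)c2c(oc(-c3ccc(O)c(C)c3C)cc2=O)C(CC)(CC)C1=O`, has not yet been measured. It differs from compound 2 in one place: 4-hydroxy-2,3-dimethylphenyl in place of 2,4-dimethylphenyl on an aromatic carbon. Within the data shown here, no measured step shows what adding a hydroxy group to this aryl ring does on the shared core; the only step available, from compound 1 to compound 2, exchanged one substituted phenyl for another and stayed within the scatter. Among the measured compounds shown here, with no step pointing in either direction, the expectation for compound 3 in this assay is a number close to that of compound 2, with an expected step of a 1.1-fold higher number from compound 2 to compound 3 (0.02 log units; within the scatter) that stays within the scatter. Compound 3 is therefore estimated at 9 uM, in a range from 3.5 uM to 25 uM.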

Compound 3, concentration for half-maximal effect: 2.75 uM
Estimate against measurement, compound 3: 3.3-fold (0.51 log units) above; the measured number lies below the stated range.
By their numbers in this assay, from the lowest: compound 3; then compounds 2 and 1 (each within the scatter of the next).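

Unlike the exchange of one substituted phenyl for another between the first two compounds, this change on the aromatic carbon next to the ring oxygen moves the number beyond the scatter: this assay shows a 3.1-fold lower number from compound 2 to compound 3 (0.49 log units; beyond the scatter) and also a 5.7-fold lower number from compound 1 to compound 3 (0.76 log units; beyond the scatter). The aryl group at this place on the shared core can therefore shift the antiproliferative number by more than repeat measurements would, and compound 3 now stands lowest of the three, with its steps to both others beyond the scatter. The 4-hydroxy-2,3-dimethylphenyl group differs from 2,4-dimethylphenyl both in carrying a hydroxy group and in the numbering of its methyl groups, and nothing available explains the drop.

From the compounds shown here alone, what remains open is which of those two differences carries the step, a question that a plain 2,3-dimethylphenyl group on the same core would help to separate. Going by these compounds, it is also open whether the hydroxy group itself matters, or whether a methoxy or an amino group at that place on the ring would give a similar number in this assay on these cells.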